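Taking the amino group away: one measured neighbour

A few compounds are considered here, and "the series" means these few. Any claim that something is new, unique, unknown or untested is made for them only; others in the source may bear on it.

Three compounds share one core here, but the numbers are thin. Compound 1 (`COc1ccc(/C=C/C(=O)c2cccc(Br)c2)cc1OC`) has "not determined" (no result reported) as its entry in a functional assay on CNE-2 cells (Homo sapiens) for cytotoxicity, read by sulforhodamine B assay, with a stated time of 48 h (on this read-out higher numbers stand for weaker inhibition and lower numbers for stronger inhibition), and so offers nothing to compare. Within the data shown here, compound 2 (`COc1ccc(/C=C/C(=O)c2ccc(N)c(-c3ccc(F)cc3)c2)cc1OC`) reads 3510 nM in this assay and is the only measured value so far, so it cannot yet be ranked against anything. Compound 3 (`COc1ccc(/C=C/C(=O)c2cccc(-c3ccc(F)cc3)c2)cc1OC`) alters compound 2 in one place, with hydrogen in place of amino on an aromatic carbon. Among the measured compounds shown here, no measured pair shows what this swap does, so only a modest shift towards weaker inhibition is expected, and it may stay within the usual scatter. The estimated change (a 1.4-fold higher number from compound 2 to compound 3 (0.15 log units; within the scatter)) rests on compound 2 alone (3510 nM). For compound 3 the expected value in this assay is 5000 nM (estimated range 1800 nM to 15000 nM).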

Compound 3, half-maximal inhibitory concentration: 5550 nM
Beside the measured number, compound 3's estimate is 1.1-fold (0.05 log units) below it; measured number inside the range.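

In this assay, among these compounds, replacing amino with hydrogen gives a 1.6-fold higher number from compound 2 to compound 3 (0.20 log units; within the scatter) and is the first measured test of this position, ortho to a 4-fluorophenyl group. The amino group can therefore be lost here without a change that stands out from ordinary repeat-to-repeat variation, so this pair gives no sign that it matters for the cytotoxicity read-out. (Nothing available offers a reason for this result)

From the compounds shown here alone, it remains open whether a different group at this position, such as a hydroxyl, a methoxy or an acetamide, would move the number clearly beyond that variation. Going by these compounds, the role of the 4-fluorophenyl group also remains open, for instance what would happen with a small methyl group in its place.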